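A few compounds are considered here, and "the series" means these few. Any claim that something is new, unique, unknown or untested is made for them only; others in the source may bear on it.

Measured compounds:
compound 1 `CN(C)CCn1cnnc1-c1cc(Oc2ccc(NC(=O)N/N=C/c3ccc(Cl)cc3)cc2F)ccn1` with 1870 nM
compound 2 `CN(C)CCn1cnnc1-c1cc(Oc2ccc(NC(=O)N/N=C/c3c(O)ccc4ccccc34)cc2F)ccn1` with 3250 nM
compound 3 `Cc1cc(/C=N/NC(=O)Nc2ccc(Oc3ccnc(-c4nncn4CCN(C)C)c3)c(F)c2)cc(C)c1O` with 3610 nM

In an ADME assay on WI-38 cells (Homo sapiens) for cytotoxicity, read by MTT assay, with a stated time of 72 h (on this read-out higher numbers stand for weaker inhibition and lower numbers for stronger inhibition), compound 3 carries the highest of the three numbers, but its separation from the others is small: a 1.1-fold higher number from compound 2 to compound 3 (0.05 log units; within the scatter) and a 1.9-fold higher number from compound 1 to compound 3 (0.29 log units; within the scatter). All three compounds therefore sit in one band, and none can be called weaker or stronger than another.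

Compound 4 `CN(C)CCn1cnnc1-c1cc(Oc2ccc(NC(=O)N/N=C/c3ccc(Cl)cc3Cl)cc2F)ccn1` is the next member of the series. Its change from compound 3 is 2,4-dichlorophenyl in place of 4-hydroxy-3,5-dimethylphenyl on a carbon with a double bond to nitrogen. Among the compounds with values here, the step that bears most directly on it is the one between compound 1, which carries 4-chlorophenyl at the same carbon, and compound 3: a 1.9-fold higher number from compound 1 to compound 3 (0.29 log units; within the scatter), within the scatter. The other replacement at this position, a 1.7-fold higher number from compound 1 to compound 2 (0.24 log units; within the scatter), was also within the scatter. Swapping aryl groups at this carbon has so far left the read-out essentially unchanged, so compound 4 is expected to fall in the same band, if anything closer to compound 1.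

The step of a 1.7-fold lower number from compound 3 to compound 4 (0.24 log units; within the scatter) is expected to stay within the scatter. Compound 4 is estimated at 2100 nM, with a range from 900 nM to 4800 nM.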

Compound 4, half-maximal inhibitory concentration: 4760 nM
Estimate against measurement, compound 4: 2.3-fold (0.36 log units) below, and the stated range covers the measured number.
By their numbers in this assay, from the lowest: compounds 1, 2, 3 and 4 (each within the scatter of the next, the first and the last beyond it).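

In this assay, within the data shown here, chloro in place of hydrogen on an aromatic carbon gives a 2.5-fold higher number from compound 1 to compound 4 (0.41 log units; beyond the scatter) and is the first step at this carbon to pass beyond the scatter, though only modestly. The other two new steps, a 1.3-fold higher number from compound 3 to compound 4 (0.12 log units; within the scatter) and a 1.5-fold higher number from compound 2 to compound 4 (0.17 log units; within the scatter), stay within it, and compound 2 and compound 3 remain within the scatter of compound 1, so only the two chlorophenyl compounds, compound 1 and compound 4, stand apart. Nothing available accounts for this separation.

The compounds shown leave open whether 2-chlorophenyl alone would give a number like that of compound 4 or one like that of compound 1. They also leave open how this read-out would respond to an aryl group carrying an amine or a carboxylic acid at this carbon.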